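Moving from 3-methoxyphenyl to 4-methoxyphenyl: working notes

This account rests on a few compounds, and the source may have more. Where it says the series, first, only, none or still open, it means among the compounds named here.

In a functional assay on THP-1 cells (Homo sapiens) for inhibition, read by sulforhodamine B assay, with a stated time of 48 h, tested at 50 uM (on this read-out higher numbers stand for more inhibition of growth at the one concentration tested and lower numbers for less inhibition of growth), compound 3 `COc1cccc(/C=C/C(=O)/C=C/c2ccc(OCc3cn(CCCOc4cc(=O)oc5ccccc45)nn3)c(OC)c2)c1` gives 58%. Compound 2 `COc1cc(/C=C/C(=O)/C=C/c2ccco2)ccc1OCc1cn(CCCOc2cc(=O)oc3ccccc23)nn1` gives 57%, and the two sit level, with a number 1 percentage points higher from compound 2 to compound 3 (within the scatter). Compound 1 `COc1cc(/C=C/C(=O)/C=C/c2cccc3ccccc23)ccc1OCc1cn(CCCOc2cc(=O)oc3ccccc23)nn1` gives 71%, which leaves compound 3 in the lower pair, with a number 13 percentage points lower from compound 1 to compound 3 (beyond the scatter). Furan-2-yl in place of naphthalen-1-yl gives a similar modest drop, a number 14 percentage points lower from compound 1 to compound 2 (beyond the scatter).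

Compound 4 `COc1ccc(/C=C/C(=O)/C=C/c2ccc(OCc3cn(CCCOc4cc(=O)oc5ccccc45)nn3)c(OC)c2)cc1` is next: 4-methoxyphenyl in place of 3-methoxyphenyl on a double-bonded chain carbon bound to a double-bonded chain carbon. In words, 4-methoxyphenyl stands in place of 3-methoxyphenyl on a double-bonded chain carbon bound to a double-bonded chain carbon. All three measured steps exchange the group at this place, but none compares two methoxyphenyl groups, so they bear only indirectly. The two steps away from naphthalen-1-yl were modest, and the step from furan-2-yl to 3-methoxyphenyl stayed within the scatter. No step beyond the scatter is therefore expected, and the estimated change is a number 1 percentage points higher from compound 3 to compound 4 (within the scatter). The estimate for compound 4 is 59%, with an expected range of 46% to 72%.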

Compound 4, percent growth inhibition at one concentration: 56%
Compound 4: middle estimate off by 3 percentage points, on the high side, within the range that was stated.
By their numbers in this assay, from the lowest: compounds 4, 2 and 3 (each within the scatter of the next); then compound 1.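

In this assay, among the compounds shown here, this is the first direct comparison of two methoxyphenyl groups on a double-bonded chain carbon bound to a double-bonded chain carbon, and it gives a step within the scatter (a number 2 percentage points lower from compound 3 to compound 4 (within the scatter)), so 4-methoxyphenyl cannot be told apart from 3-methoxyphenyl here. 4-methoxyphenyl also cannot be told apart from furan-2-yl (a number 1 percentage points lower from compound 2 to compound 4 (within the scatter)), while naphthalen-1-yl stays clear of it (a number 15 percentage points lower from compound 1 to compound 4 (beyond the scatter)), which leaves three different groups together and only naphthalen-1-yl apart among the four compounds. No measurement at hand accounts for any of these steps.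

From the compounds shown here alone, whether the higher number belongs to naphthalen-1-yl specifically or would also appear with naphthalen-2-yl remains open. So does the outcome with 2-methoxyphenyl, or with an amine or a carboxylic acid at this place.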